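Bromo added to the core of compound 3

The compounds below may be only part of what the source reports. "The series", "measured", "known", "first", "only" and "open" are said of these compounds alone.

In a functional assay on PC-3 cells (Homo sapiens) (a lower number here means a stronger inhibitor of growth, a higher number a weaker inhibitor of growth), compound 3 `O=S(=O)(/C=C/c1ccc(Cl)cc1)Cc1ccc(Nc2ncnc3ccccc23)cc1` gives 43000 nM, within the scatter of compound 2 `O=S(=O)(/C=C/c1ccc(Br)cc1)Cc1ccc(Nc2ncnc3ccccc23)cc1` at 42000 nM. Compound 1 `N#Cc1ccc(/C=C/S(=O)(=O)Cc2ccc(Nc3ncnc4ccccc34)cc2)cc1` gives only a limit, > 100000 nM. Compound 4 `O=S(=O)(/C=C/c1ccc(Cl)cc1)Cc1ccc(Nc2ncnc3ccc(Br)cc23)cc1` differs from compound 3 by bromo in place of hydrogen on an aromatic carbon of the fused system of two rings. For the measured compounds named here, no measured step changes this position, so the evidence is indirect. The exchange of halogens gives a 1.0-fold higher number from compound 2 to compound 3 (0.01 log units; within the scatter), while halogen for nitrile gives an at least 2.3-fold lower number from compound 1 to compound 2 (0.37 log units; beyond the scatter) and an at least 2.3-fold lower number from compound 1 to compound 3 (0.36 log units; beyond the scatter). On that loose analogy, the expected change is modest and uncertain in direction, leaning lower: a 1.7-fold lower number from compound 3 to compound 4 (0.24 log units; within the scatter). For compound 4 the estimated value is 25000 nM, with an expected range of 6000 nM to 90000 nM.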

Compound 4, concentration for 50% growth inhibition: 2000 nM
Compound 4: the middle estimate sits 13-fold (1.10 log units) above what was measured; the measured number lies below the stated range.
By their numbers in this assay, from the lowest: compound 4; then compounds 2 and 3 (each within the scatter of the next). At a limit, above all of these: compound 1.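

In this assay, a 22-fold lower number from compound 3 to compound 4 (1.33 log units; beyond the scatter) for bromo in place of hydrogen on an aromatic carbon of the fused system of two rings. This position of the shared core, unchanged across compounds 1 to 3, therefore responds strongly to a single heavy atom, whereas chloro in place of bromo elsewhere gave a 1.0-fold higher number from compound 2 to compound 3 (0.01 log units; within the scatter). The data do not show what lies behind this step.

Open, from the compounds shown here alone, is whether chloro, a methoxy group or an amine at this carbon would give a similar step. Also open, going by these compounds, is whether the step would hold with nitrile in place of the chloro of compound 4.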